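The compounds below may be only part of what the source reports. "The series", "measured", "known", "first", "only" and "open" are said of these compounds alone.

Among the measured compounds shown here, compound 2 `Cc1ccc(S(=O)(=O)/N=C(/CCNC2=CC(=O)c3ccccc3C2=O)Nc2cccc(C(F)(F)F)c2)cc1` gives 84100 nM in a functional assay on DU-145 cells (Homo sapiens) for cytotoxicity, read by MTT assay, with a stated time of 48 h (on this read-out higher numbers stand for weaker inhibition and lower numbers for stronger inhibition), the higher of the two numbers measured so far; compound 1 `COc1ccc(N/C(CCNC2=CC(=O)c3ccccc3C2=O)=N\S(=O)(=O)c2ccc(C)cc2)cc1` gives 12000 nM. Compound 3 `Cc1ccc(S(=O)(=O)/N=C(/CCNC2=CC(=O)c3ccccc3C2=O)Nc2ccc(Cl)cc2Cl)cc1` differs from compound 2 by 2,4-dichlorophenyl in place of 3-(trifluoromethyl)phenyl on an amine nitrogen. For the measured compounds named here, no measured step covers this exchange directly; the single known step, a 7.0-fold higher number from compound 1 to compound 2 (0.85 log units; beyond the scatter), shows only that swapping the group on this amine nitrogen can shift this assay by that much. The expected step of a 2.4-fold lower number from compound 2 to compound 3 (0.38 log units; beyond the scatter) is therefore modest, its direction uncertain. The estimate for compound 3 is 35000 nM, in a range from 8000 nM to 120000 nM.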

Compound 3, half-maximal inhibitory concentration: 18600 nM
Estimate against measurement, compound 3: 1.9-fold (0.27 log units) above, within the range that was stated.
By their numbers in this assay, from the lowest: compounds 1 and 3 (each within the scatter of the next); then compound 2.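

In this assay the swap to 2,4-dichlorophenyl on this amine nitrogen gives a 4.5-fold lower number from compound 2 to compound 3 (0.66 log units; beyond the scatter) and so separates compound 3 from compound 2 by more than the scatter. The same group in place of 4-methoxyphenyl gives a 1.6-fold higher number from compound 1 to compound 3 (0.19 log units; within the scatter) and leaves compound 1 and compound 3 within the scatter of each other, so compound 2 alone stands apart among the three. Nothing measured here accounts for this difference. The compounds shown leave open what a plain phenyl or a pyridine ring on this nitrogen would give, and whether a longer chain in the linker would shift these numbers.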